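Replacing the aryl group of compound 3

The compounds below may be only part of what the source reports. "The series", "measured", "known", "first", "only" and "open" are said of these compounds alone.

Compound 1 `O=C(N/N=C/c1ccc(F)cc1Cl)Nc1cc2c(Nc3ccc(F)c(Cl)c3)ncnc2cc1O[C@H]1CCOC1` gives 27200 nM
Compound 2 `O=C(N/N=C/c1ccc(O)c(Br)c1)Nc1cc2c(Nc3ccc(F)c(Cl)c3)ncnc2cc1O[C@H]1CCOC1` gives 4310 nM
Compound 3 `COc1cc2ncnc(Nc3ccc(F)c(Cl)c3)c2cc1NC(=O)N/N=C/c1ccc(F)cc1Cl` gives 28200 nM

All three numbers come from a functional assay on A549 cells (Homo sapiens) for cytotoxicity, read by MTT assay, with a stated time of 72 h (on this read-out lower numbers stand for stronger inhibition and higher numbers for weaker inhibition), and can be compared directly. Compound 3 stands with compound 1 at the weak end of the three, and the two cannot be told apart: the measured change is a 1.0-fold higher number from compound 1 to compound 3 (0.02 log units; within the scatter) and comes from methyl in place of oxolan-3-yl on an oxygen on an aromatic ring.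

The next compound is compound 4 `COc1cc2ncnc(Nc3ccc(F)c(Cl)c3)c2cc1NC(=O)N/N=C/c1cc(Br)c(O)c(Br)c1` and its change from compound 3 is 3,5-dibromo-4-hydroxyphenyl in place of 2-chloro-4-fluorophenyl on a carbon with a double bond to nitrogen and, in words, 3,5-dibromo-4-hydroxyphenyl in place of 2-chloro-4-fluorophenyl on a carbon with a double bond to nitrogen.

The closest measured parallel is 3-bromo-4-hydroxyphenyl in place of the same 2-chloro-4-fluorophenyl, which gave a 6.3-fold lower number from compound 1 to compound 2 (0.80 log units; beyond the scatter) and counts as modest. Compound 1 and compound 3 read alike, so a drop of similar size is expected here, though this rests on a single pair. Within the data shown here, no measured compound carries 3,5-dibromo-4-hydroxyphenyl, so the range must stay wide. In this assay the expected step is a 6.3-fold lower number from compound 3 to compound 4 (0.80 log units; beyond the scatter) (beyond the scatter). Compound 4 is estimated at 4500 nM (expected range 1500 nM to 14000 nM).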

Compound 4, half-maximal inhibitory concentration: 34600 nM
The estimate for compound 4 lay 7.7-fold (0.89 log units) below the measured number, outside the stated range (above it).
By their numbers in this assay, from the lowest: compound 2; then compounds 1, 3 and 4 (each within the scatter of the next).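

In this assay, placing 3,5-dibromo-4-hydroxyphenyl on the carbon with a double bond to nitrogen gives a 1.2-fold higher number from compound 3 to compound 4 (0.09 log units; within the scatter), so this change has no measurable effect. A hydroxyl and bromine on the aryl ring therefore do not by themselves guarantee a lower number, even though 3-bromo-4-hydroxyphenyl gave a 6.3-fold lower number from compound 1 to compound 2 (0.80 log units; beyond the scatter) when it replaced the same 2-chloro-4-fluorophenyl on the oxolan-3-yl ether. No measurement here explains why these two steps differ.

The two steps differ in both the incoming aryl group and the group on the oxygen, so the compounds shown cannot separate the effect of 3,5-dibromo-4-hydroxyphenyl versus 3-bromo-4-hydroxyphenyl from that of methyl versus oxolan-3-yl; pairing methyl with 3-bromo-4-hydroxyphenyl, or oxolan-3-yl with 3,5-dibromo-4-hydroxyphenyl, would address this directly. From the compounds shown here alone, it also remains open how this position would respond to an aryl group carrying an amine or a carboxylic acid.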